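Adding chloro to the 2-phenylethenyl group of compound 3

A few compounds are considered here, and "the series" means these few. Any claim that something is new, unique, unknown or untested is made for them only; others in the source may bear on it.

Within the data shown here, in a functional assay on MCF7 cells (Homo sapiens) for inhibition, read by MTT assay, with a stated time of 48 h, tested at 10 uM (a higher number here means more inhibition of growth at the concentration tested, a lower number less inhibition of growth), compound 3 `CN1CC[C@H](c2c(O)cc(O)c3c(=O)cc(/C=C/c4ccccc4)oc23)[C@H](O)C1` gives 8%, the lowest of the three numbers so far and beyond the scatter from both of the others. Compound 1 `CCN(CC)Cc1c(O)c([C@H]2CCN(C)C[C@H]2O)c2oc(C)cc(=O)c2c1O` gives 24%. Compound 2 `Cc1cc(=O)c2c(O)c(CN3CC(O)CC3C(=O)O)c(O)c([C@H]3CCN(C)C[C@H]3O)c2o1` gives 25%.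

Compound 4 `CN1CC[C@H](c2c(O)cc(O)c3c(=O)cc(/C=C/c4ccc(Cl)cc4)oc23)[C@H](O)C1` carries a 2-(4-chlorophenyl)ethenyl group where compound 3 has 2-phenylethenyl: chloro in place of hydrogen on an aromatic carbon, para to a large group (chloro in place of hydrogen on an aromatic carbon).

Among the measured compounds shown here, only one measured step is available, a number 1 percentage points higher from compound 1 to compound 2 (within the scatter). It places 2-carboxy-4-hydroxypyrrolidin-1-yl where diethylamino stood on a saturated chain carbon, so it concerns a different place and a different kind of change. It is therefore a weak guide. For the measured compounds named here, no measured step touches the 2-phenylethenyl group, so the data give no firm direction. The expected change, a number 4 percentage points higher from compound 3 to compound 4 (within the scatter), is no larger than the scatter. Compound 4 is estimated at 12%, with an expected range from 2% to 27%.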

Compound 4, percent growth inhibition at one concentration: 10%
Estimate against measurement, compound 4: 2 percentage points above, and the stated range covers the measured number.
By their numbers in this assay, from the lowest: compounds 3 and 4 (each within the scatter of the next); then compounds 1 and 2 (each within the scatter of the next).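

The 2-phenylethenyl group now has its first measured step: in this assay, chloro in place of hydrogen on an aromatic carbon, para to a large group, gives a number 2 percentage points higher from compound 3 to compound 4 (within the scatter) and so does not separate the pair. The earlier step concerned only diethylamino on a saturated chain carbon and gave no reading at this position. No measurement at hand offers an explanation for this result.

From the compounds shown here alone, whether a carboxylic acid, an amine or a methoxy group on this same aromatic carbon would give a step beyond the scatter remains open. Also open, going by these compounds, is whether chloro here would read the same on a compound that also carries the diethylamino chain of compound 1.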